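Replacing hydroxy with carboxy on a trifluoromethyl compound

The compounds below may be only part of what the source reports. "The series", "measured", "known", "first", "only" and "open" are said of these compounds alone.

Compound 1 `Cc1c(C(=O)Nc2c(F)cc(-c3cccc(F)c3)cc2F)nc2ccc(F)cc2c1O`: 65300 nM
Compound 2 `Cc1c(C(=O)Nc2c(F)cc(-c3cccc(F)c3)cc2F)nc2ccc(C(F)(F)F)cc2c1O`: 12600 nM

In a functional assay on A-375 cells (Homo sapiens) for antiproliferative activity, read by MTT assay, with a stated time of 24 h (on this read-out higher numbers stand for weaker inhibition and lower numbers for stronger inhibition), compound 2 has the lower of the two numbers, at 12600 nM. Compound 3 `Cc1c(C(=O)Nc2c(F)cc(-c3cccc(F)c3)cc2F)nc2ccc(C(F)(F)F)cc2c1C(=O)O` differs from it in one group: carboxy in place of hydroxy on an aromatic carbon. Within the data shown here, the only measured step, a 5.2-fold lower number from compound 1 to compound 2 (0.71 log units; beyond the scatter), changed a different place, so it guides the size of the next step but not its direction. No measurement covers this change, which leaves the forecast uncertain. A similar step towards a lower number is expected in this assay, estimated as a 4.2-fold lower number from compound 2 to compound 3 (0.62 log units; beyond the scatter). For compound 3 the estimated value is 3000 nM, with an expected range of 300 nM to 25000 nM.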

Compound 3, half-maximal inhibitory concentration: 42800 nM
Compound 3: middle estimate off by 14-fold (1.15 log units), on the low side, outside the stated range (above it).
By their numbers in this assay, from the lowest: compound 2; then compounds 3 and 1 (each within the scatter of the next).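

In this assay, carboxy in place of hydroxy on the aromatic carbon opposite the ring nitrogen gives a 3.4-fold higher number from compound 2 to compound 3 (0.53 log units; beyond the scatter) and so moves the number towards weaker inhibition. Among these compounds, this is the first reading at this position, which does respond to a change of group; the earlier step changed a different place. Nothing measured here gives a reason for this step. As far as these compounds go, whether an amine or a methyl ester at this position would behave like carboxy stays open, as does whether the same change would give a similar step on the fluoro compound.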